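Working notes: from compound 3 to compound 4

The source may report more compounds than this note shows. Statements on the series, on what has been measured and on what is new or still open speak of the compounds shown alone.

Measured in a functional assay on HOS cells (Homo sapiens) for antiproliferative activity, with a stated time of 72 h; a lower number here means a stronger inhibitor, a higher number a weaker inhibitor:
- Compound 1 `OC[C@H]1O[C@@H](n2cnc3c(NCc4ccccc4Br)ncnc32)[C@H](O)[C@@H]1O`: > 166000 nM (a limit)
- Compound 2 `COc1cccc(CNc2ncnc3c2ncn3[C@@H]2O[C@H](CO)[C@@H](O)[C@H]2O)c1OC`: > 166000 nM (a limit)
- Compound 3 `OC[C@H]1O[C@@H](n2cnc3c(NCc4c(F)ccc(F)c4F)ncnc32)[C@H](O)[C@@H]1O`: "not determined" (no result reported)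

Compound 3 has no single number in this assay, so its standing can only be read from the two other compounds. Both of these sit at the limit of > 166000 nM in this assay, at which 2 of the 3 values shown sit, which is a limit of the assay and not a number. Within the data shown here, the only measured step is a step that the two limits leave unreadable from compound 1 to compound 2, and it gives no size to carry forward.

The change to compound 4 `OC[C@H]1O[C@@H](n2cnc3c(NCc4cccc(C(F)(F)F)c4)ncnc32)[C@H](O)[C@@H]1O` is 3-(trifluoromethyl)phenyl in place of 2,3,6-trifluorophenyl on a saturated chain carbon bound to a nitrogen on an aromatic ring. In words, 3-(trifluoromethyl)phenyl stands in place of 2,3,6-trifluorophenyl on a saturated chain carbon bound to a nitrogen on an aromatic ring.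

With no number for compound 3, no step size or direction can be stated from it. Compound 4 is expected to stay weak, at or close to the same limit, and a report of the limit alone is the likeliest outcome. For compound 4 the estimated value is 130000 nM, with an expected range from 40000 nM to 166000 nM.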

Compound 4, half-maximal inhibitory concentration: > 166000 nM
Compound 4 was reported as a limit; the forecaster's own chance of this, stated with the estimate: 65%; at least 1.2-fold (0.10 log units) between middle value and limit.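

In this assay compound 4 gives > 166000 nM, which is a limit of the assay and not a number. Among these compounds, no new step can therefore be read from compound 1 or compound 2 to compound 4. The compounds shown leave open how compound 1, compound 2 and compound 4 rank against one another.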